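Amide to urea at the shared core: compound 1 to compound 3

A few compounds are considered here, and "the series" means these few. Any claim that something is new, unique, unknown or untested is made for them only; others in the source may bear on it.

Measured so far:
compound 1, `COc1cc(-c2nn(-c3cccc(NC(=O)c4cccc(C(F)(F)F)c4)c3)cc2-c2ccncc2)ccc1Cl`: > 50000 nM
compound 2, `O=C(Nc1cccc(-n2cc(-c3ccncc3)c(-c3ccc(Cl)c(O)c3)n2)c1)Nc1ccc(Cl)c(C(F)(F)F)c1`: 17400 nM

In a functional assay on KM12 cells (Homo sapiens) for inhibition, read by sulforhodamine B assay, with a stated time of 48 h (a lower number here means that less compound is tolerated, a higher number that more compound is tolerated), compound 1 gives > 50000 nM, which is a limit of the assay and not a number. Compound 2 gives 17400 nM in this assay. For the measured compounds named here, compound 1 thus sits at the limit of > 50000 nM in this assay, at which 1 of the 2 values shown sits, and no measured step to another compound is known for it.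

Compound 3, `COc1cc(-c2nn(-c3cccc(NC(=O)Nc4ccc(Cl)c(Cl)c4)c3)cc2-c2ccncc2)ccc1Cl`, is not yet measured. It differs from compound 1 in one place: (3,4-dichlorophenyl)amino in place of 3-(trifluoromethyl)phenyl on a carbonyl carbon.

Since compound 1 is known only as a limit, the size of the step cannot be anchored; an expected move toward lower values, beyond the scatter, is estimated as an at least 3.3-fold lower number from compound 1 to compound 3 (0.52 log units; beyond the scatter). The value of compound 3 in this assay is expected to lie near 15000 nM, estimated between 5000 nM and 50000 nM.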

Compound 3, concentration lethal to 50% of the cells: 49500 nM
Beside the measured number, compound 3's estimate is 3.3-fold (0.52 log units) below it; the measured number falls inside the stated range.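

At this position, on a carbonyl carbon whose other neighbour is an amide-type nitrogen, the change gives in this assay a number no higher from compound 1 to compound 3 (the limit leaves the size open). Compound 1 gives > 50000 nM, which is a limit of the assay and not a number. Compound 3, with (3,4-dichlorophenyl)amino at this place, gives a readable number, 49500 nM, so this shared core can yield a measured value with the urea. The size of the step cannot be read because one end of it is a limit: the limit of > 50000 nM in this assay, at which 1 of the 3 values shown sits.

The compounds shown leave open whether the entering amino nitrogen or the two chlorines account for the result. A (3-(trifluoromethyl)phenyl)amino group or a 3,4-dichlorophenyl group on the same carbonyl carbon would separate the two.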